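The source may report more compounds than this note shows. Statements on the series, on what has been measured and on what is new or still open speak of the compounds shown alone.

Measured compounds:
Compound 1, `O=C(NCc1ccncc1)Nc1ccc(S(=O)(=O)N2CC3CCC(C2)O3)cc1`: 279 nM
Compound 2, `NS(=O)(=O)c1ccc(NC(=O)NCc2ccncc2)cc1`: 14300 nM
Compound 3, `CN(C1CCCC1)S(=O)(=O)c1ccc(NC(=O)NCc2ccncc2)cc1`: 123 nM

In an assay on isolated protein for activation of Nicotinamide phosphoribosyltransferase (Homo sapiens) (a lower number here means that less compound is needed, a higher number that more compound is needed for the effect), compound 3 stands lowest of the three, with compound 1 nearest and compound 2 furthest from it. Compound 4, `O=C(NCc1ccncc1)Nc1ccc(S(=O)(=O)c2cccc(Cl)c2)cc1`, differs from compound 3 by 3-chlorophenyl in place of cyclopentyl(methyl)amino on a sulfonyl sulfur. Among the measured compounds shown here, two measured steps bear on changes at the sulfonyl sulfur: a 2.3-fold lower number from compound 1 to compound 3 (0.36 log units; beyond the scatter) was modest, whereas a 120-fold lower number from compound 2 to compound 3 (2.07 log units; beyond the scatter) was large. Exchanging one sizeable group for another at this sulfur has so far moved the number little, while reducing it to a bare amino moved it greatly. The entering 3-chlorophenyl keeps the sulfur fully substituted. A modest step, if any, in this assay is therefore expected for compound 4, as a 2.0-fold higher number from compound 3 to compound 4 (0.31 log units; beyond the scatter). Compound 4 is estimated at 250 nM, within a range from 80 nM to 800 nM.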

Compound 4, half-maximal effective concentration: 69 nM
Compound 4: the middle estimate sits 3.6-fold (0.56 log units) above what was measured; measured number outside the range, below it.
By their numbers in this assay, from the lowest: compounds 4 and 3 (each within the scatter of the next); then compound 1; then compound 2.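

In this assay, the sulfonyl sulfur need not carry a nitrogen: 3-chlorophenyl, a ring of carbon only, and cyclopentyl(methyl)amino cannot be told apart, with a 1.8-fold lower number from compound 3 to compound 4 (0.25 log units; within the scatter). The step from the bare amino is large, a 210-fold lower number from compound 2 to compound 4 (2.32 log units; beyond the scatter), and the step from the group with two non-aromatic rings is modest, a 4.0-fold lower number from compound 1 to compound 4 (0.61 log units; beyond the scatter). No measurement at hand accounts for these steps. On these data alone, whether the chlorine contributes at all remains open, and a plain phenyl on the sulfur would test this. A small methyl there would show how much of the group the sulfur needs.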